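Swapping one ring nitrogen for carbon at the chain end

A few compounds are considered here, and "the series" means these few. Any claim that something is new, unique, unknown or untested is made for them only; others in the source may bear on it.

Among the compounds with values here, compound 1 `COc1cc2c(Oc3ccc(NC(=O)c4nn(-c5ccc(Br)cc5)c(=O)c5ccccc45)cc3F)ccnc2cc1OCCCN1CCN(C)CC1` is one of two compounds measured here in a functional assay on MKN-45 cells (Homo sapiens) for cytotoxicity, read by MTT assay, with a stated time of 72 h; a lower number here means a stronger inhibitor, a higher number a weaker inhibitor. In this assay compound 1 gives 350 nM, the lower of the two numbers, and compound 2 `COc1cc2c(Oc3ccc(NC(=O)c4nn(-c5ccccc5Br)c(=O)c5ccccc45)cc3F)ccnc2cc1OCCCN1CCN(C)CC1` gives 400 nM. Within the data shown here, the only measured step, a 1.1-fold higher number from compound 1 to compound 2 (0.06 log units; within the scatter), moves a bromine on the ring attached to the aromatic nitrogen and stays within the scatter, so the two values tell the same story.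

Compound 3 `COc1cc2c(Oc3ccc(NC(=O)c4nn(-c5ccc(Br)cc5)c(=O)c5ccccc45)cc3F)ccnc2cc1OCCCN1CCC(C)CC1` differs from compound 1 at the far end of the chain that hangs from the aromatic oxygen: 4-methylpiperidin-1-yl in place of 4-methylpiperazin-1-yl on a saturated chain carbon, three bonds along the chain from an oxygen on an aromatic ring. Among the measured compounds shown here, no measured step touches this part of the molecule; the one step known alters the brominated ring, not the saturated chain end. For the measured compounds named here, the change keeps the size of the group and removes one ring nitrogen, and there is no measured pair to say how that reads in this assay. The expectation is therefore a step of a 1.1-fold higher number from compound 1 to compound 3 (0.06 log units; within the scatter), with no direction argued beyond the scatter. Compound 3 is estimated at 400 nM, within a range from 150 nM to 1100 nM.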

Compound 3, half-maximal inhibitory concentration: 330 nM
For compound 3 the middle estimate is 1.2-fold (0.08 log units) above the measured one; measured number inside the range.
By their numbers in this assay, from the lowest: compounds 3, 1 and 2 (each within the scatter of the next).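

In this assay, within the data shown here, 4-methylpiperidin-1-yl in place of 4-methylpiperazin-1-yl on a saturated chain carbon gives a 1.1-fold lower number from compound 1 to compound 3 (0.03 log units; within the scatter), which is the first measured step at this end of the molecule; the earlier step changed only the brominated ring. The change replaces one ring nitrogen with carbon, taking the hydrogen-bond acceptors counted for the group from 2 to 1 while keeping its 7 heavy atoms and six-membered ring, and in this single pair the cell read-out does not separate the two compounds. So this position can carry either group without a difference that can be told from ordinary assay scatter, although one pair cannot establish a wider rule, and no supporting data here explain the result.

The compounds shown leave open whether a less closely related group at the same chain end, such as morpholin-4-yl, a dimethylamino group or a carboxylic acid, would also stay within the scatter. They also leave open how a longer chain would read, and whether the same piperazine-to-piperidine swap would give a similar result with the 2-bromophenyl group of compound 2.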